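The source may report more compounds than this note shows. Statements on the series, on what has been measured and on what is new or still open speak of the compounds shown alone.

Measured so far, with the one open compound:
- compound 1 `COc1cc(OC)c(C(=O)/C=C/c2ccccc2Cl)c(O)c1CN1CCCCC1`: 2800 nM
- compound 2 `COc1cc(OC)c(C(=O)/C=C/c2ccccc2Cl)c(O)c1CN(C)CC(=O)O`: 79400 nM
- compound 3 `COc1cc(OC)c(C(=O)/C=C/c2ccccc2Cl)c(O)c1CN(C)C`: not yet measured

In a functional assay on A549 cells (Homo sapiens) for antiproliferative activity, with a stated time of 72 h (on this read-out lower numbers stand for stronger inhibition and higher numbers for weaker inhibition), compound 2 gives 79400 nM, the highest of the two numbers. Compound 3 differs from it as follows: hydrogen in place of carboxy on a saturated chain carbon bound to an amine nitrogen. For the measured compounds named here, the one measured step bearing on this is a 28-fold higher number from compound 1 to compound 2 (1.45 log units; beyond the scatter), large and beyond the scatter. Like compound 1, compound 3 has no carboxy group, so a similarly large step towards a lower number is expected. The expected change is an 18-fold lower number from compound 2 to compound 3 (1.25 log units; beyond the scatter). For compound 3 the estimated value is 4500 nM, with an expected range of 1500 nM to 14000 nM.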

Compound 3, half-maximal inhibitory concentration: 2100 nM
Beside the measured number, compound 3's estimate is 2.1-fold (0.33 log units) above it, within the range that was stated.
By their numbers in this assay, from the lowest: compounds 3 and 1 (each within the scatter of the next); then compound 2.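

In this assay, taking away the carboxy group alone gives a 38-fold lower number from compound 2 to compound 3 (1.58 log units; beyond the scatter) and thus ties the loss in compound 2 to the carboxy group itself, not to the absence of the piperidin-1-yl ring. Dimethylamino and piperidin-1-yl are not separated on this carbon, with a 1.3-fold lower number from compound 1 to compound 3 (0.12 log units; within the scatter) as the step, so the ring is not required to reach this level of activity. No evidence on hand accounts for either step.

Still open, from the compounds shown here alone, is how an ester or amide of the carboxylic acid would read here. Also open, going by these compounds, is whether a morpholine ring or a primary amine on this carbon would hold the activity.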